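The source may hold more compounds than are shown below. What is called first, only, known or untested is meant among the compounds shown, and "the series" means these compounds.

The measured compounds are compound 1 `CC(C)NC(=O)c1cccnc1Oc1ccc(F)cc1`, compound 2 `O=C(NCc1ccccc1)c1cccnc1Oc1ccc(F)cc1` and compound 3 `O=C(Nc1ccccc1)c1cccnc1Oc1ccc(F)cc1`. In a functional assay on the whole organism with Mus musculus as the target (a higher number here means that more compound is needed for the effect, a lower number that less compound is needed), compound 1 gives 0.001 mg/kg, compound 2 gives 0.01 mg/kg, and compound 3 gives 0.001 mg/kg.

Compound 3 sits level with compound 1 at the digits shown, and the two share the lowest number of the three; compound 2 stands apart, with a 10-fold lower number from compound 2 to compound 3 (1.00 log units; beyond the scatter) separating it from compound 3.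

The unmeasured compound 4 `O=C(NCc1ccc(F)cc1)c1cccnc1Oc1ccc(F)cc1` differs from compound 3 in one place: 4-fluorobenzyl in place of phenyl on an amide-type nitrogen.

Two of the measured steps bear on this change. a 10-fold lower number from compound 2 to compound 3 (1.00 log units; beyond the scatter) shows what happened when phenyl replaced benzyl on that nitrogen, so the reverse exchange would be expected to move the number the other way by a similar amount. a 10-fold higher number from compound 1 to compound 2 (1.00 log units; beyond the scatter), where benzyl replaced isopropyl, points the same way, since the benzyl-bearing compound 2 carries the higher number. Among the compounds with values here, compound 4 carries 4-fluorobenzyl rather than plain benzyl, and no measured pair shows how that fluorine alters the number, so that part remains unknown. Compound 4 is therefore expected to come in at about 0.01 mg/kg, within 0.003 mg/kg to 0.03 mg/kg, which means an expected 10-fold higher number from compound 3 to compound 4 (1.00 log units; beyond the scatter).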

Compound 4, minimum effective dose: 0.01 mg/kg
Compound 4: the middle estimate sits on the measured number at the digits printed, and the stated range covers the measured number.
By their numbers in this assay, from the lowest: compounds 1 and 3 (each within the scatter of the next); then compounds 2 and 4 (each within the scatter of the next).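

Within the data shown here, the fluorine left unresolved by the earlier compounds can now be read directly: in this assay, fluoro in place of hydrogen on an aromatic carbon gives no change at the digits printed from compound 2 to compound 4 (within the scatter) and so does not separate 4-fluorobenzyl from benzyl on the amide-type nitrogen. The other two new comparisons place 4-fluorobenzyl with benzyl as well, since replacing phenyl brings a 10-fold higher number from compound 3 to compound 4 (1.00 log units; beyond the scatter) and replacing isopropyl brings a 10-fold higher number from compound 1 to compound 4 (1.00 log units; beyond the scatter) in the same assay. Across these four compounds, the numbers therefore fall into two groups set by the substituent on that nitrogen, with isopropyl and phenyl in one and benzyl and 4-fluorobenzyl in the other, and no compound shown goes against this split.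

The compounds shown leave open whether the same holds for a chloro or methoxy group in place of the fluorine on the benzyl group, or for a longer chain such as 2-phenylethyl on the amide-type nitrogen. Nothing available gives a reason for the split between the two groups.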